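This account rests on a few compounds, and the source may have more. Where it says the series, first, only, none or still open, it means among the compounds named here.

Measured so far in a functional assay on A-375 cells (Homo sapiens) for antiproliferative activity, read by MTT assay, with a stated time of 24 h; a higher number here means a weaker inhibitor, a lower number a stronger inhibitor:
compound 1, `Cc1c(C(=O)Nc2c(F)cc(-c3cccc(F)c3)cc2F)nc2ccc(F)cc2c1O`: 65300 nM
compound 2, `CCOc1ccc2nc(C(=O)Nc3c(F)cc(-c4cccc(F)c4)cc3F)c(C)c(O)c2c1`: > 100000 nM (a limit of the assay, not a number)
compound 3, `Cc1c(C(=O)Nc2c(F)cc(-c3cccc(F)c3)cc2F)nc2ccc(F)cc2c1C(=O)O`: 81900 nM

Compound 2 sits at the limit of > 100000 nM in this assay, at which 1 of the 3 values shown sits, so its value is a limit only. Compound 3 differs from compound 1 by carboxy in place of hydroxy on an aromatic carbon, and this gave a 1.3-fold higher number from compound 1 to compound 3 (0.10 log units; within the scatter). Compound 2 differs from compound 1 by ethoxy in place of fluoro on an aromatic carbon, which gave an at least 1.5-fold higher number from compound 1 to compound 2 (0.18 log units; that floor lies within the scatter).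

Compound 4, `CCOc1ccc2nc(C(=O)Nc3c(F)cc(-c4cccc(F)c4)cc3F)c(C)c(C(=O)O)c2c1`, is not yet measured in this assay. It stands to compound 3 as compound 2 stands to compound 1: the change is ethoxy in place of fluoro on an aromatic carbon, the same change as before, at the same place. An at least similar step is expected here, a 1.7-fold higher number from compound 3 to compound 4 (0.23 log units; within the scatter), because the earlier instance of this change gave an at least 1.5-fold higher number from compound 1 to compound 2 (0.18 log units; that floor lies within the scatter) and compound 3 already starts from a higher number than compound 1. Compound 4 is therefore expected to give about 140000 nM in this assay, likely reported as a limit, with a plausible range from 70000 nM to 300000 nM.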

Compound 4, half-maximal inhibitory concentration: 14900 nM
Beside the measured number, compound 4's estimate is 9.4-fold (0.97 log units) above it; measured number outside the range, below it.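

In this assay, ethoxy in place of fluoro on the core of compound 3 gave a 5.5-fold lower number from compound 3 to compound 4 (0.74 log units; beyond the scatter), which does not repeat what the same change did on the core of compound 1: the same change on two cores in this assay, an at least 1.5-fold higher number (0.18 log units; that floor lies within the scatter) from compound 1 to compound 2 and a 5.5-fold lower number (0.74 log units; beyond the scatter) from compound 3 to compound 4, at least 8.4-fold (0.92 log units) apart, beyond the scatter of two such steps. Carboxy in place of hydroxy on the ethoxy-bearing core gave an at least 6.7-fold lower number from compound 2 to compound 4 (0.82 log units; beyond the scatter), which likewise does not repeat the step seen with fluoro in the core: the same change on two cores in this assay, a 1.3-fold higher number (0.10 log units; within the scatter) from compound 1 to compound 3 and an at least 6.7-fold lower number (0.82 log units; beyond the scatter) from compound 2 to compound 4, at least 8.4-fold (0.92 log units) apart, beyond the scatter of two such steps. Compound 2 is held only as a limit, so both comparisons give a floor rather than a full size, and they show that in this series neither change can be carried unaltered from one core to the other, but not why, nor whether the same holds for any other change: the limit of > 100000 nM in this assay, at which 1 of the 4 values shown sits.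

The compounds shown hold only fluoro or ethoxy at the one place and only hydroxy or carboxy at the other. They leave open whether a methoxy group or a longer alkoxy chain would follow ethoxy, and whether a methyl ester or an amine would behave as the carboxy group does.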